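The source may hold more compounds than are shown below. What is called first, only, known or untested is meant among the compounds shown, and "the series" means these compounds.

Compound 2, `CCOc1ccc2c(Cl)ccnc2c1`, and compound 3, `CCOc1ccc2c(NCCN(C)C)ccnc2c1`, share a core, and the two differ in one place: (2-(dimethylamino)ethyl)amino in place of chloro on an aromatic carbon. In a functional assay on HCT-116 cells (Homo sapiens) for cytotoxicity, read by MTT assay, with a stated time of 48 h (on this read-out lower numbers stand for stronger inhibition and higher numbers for weaker inhibition), compound 2 gives 3160 nM, and compound 3 gives 2570 nM, so that a 1.2-fold lower number from compound 2 to compound 3 (0.09 log units; within the scatter). Compound 1, `CCCCCCOc1ccc2c(Cl)ccnc2c1`, is built from compound 2 by a change on the side chain, (butyl in place of hydrogen on a saturated chain carbon, two bonds along the chain from an oxygen on an aromatic ring), and in this assay compound 1 gives 2440 nM; the step of a 1.3-fold lower number from compound 2 to compound 1 (0.11 log units; within the scatter) therefore keeps the two within the usual scatter of each other.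

Compound 4, `CCCCCCOc1ccc2c(NCCN(C)C)ccnc2c1`, is not yet measured. It stands to compound 3 as compound 1 stands to compound 2: the change is butyl in place of hydrogen on a saturated chain carbon, two bonds along the chain from an oxygen on an aromatic ring, and the place where it occurs is the same as in the measured pair, on a saturated chain carbon, two bonds along the chain from an oxygen on an aromatic ring. This change has been seen once among the measured compounds, where it gave a 1.3-fold lower number from compound 2 to compound 1 (0.11 log units; within the scatter).

Within the data shown here, since the only measured instance of this change, a 1.3-fold lower number from compound 2 to compound 1 (0.11 log units; within the scatter), stayed within the scatter, the step for compound 4 is expected to be small as well, about a 1.3-fold lower number from compound 3 to compound 4 (0.11 log units; within the scatter), resting on the behaviour of compound 1 against compound 2. On that basis compound 4 is estimated to give 2000 nM in this assay, with a likely range from 1000 nM to 4500 nM.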

Compound 4, half-maximal inhibitory concentration in the HCT-116 assay: 850 nM
Beside the measured number, compound 4's estimate is 2.4-fold (0.37 log units) above it; measured number outside the range, below it.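

In the HCT-116 assay, butyl in place of hydrogen on the saturated chain carbon, two bonds along the chain from the oxygen on the aromatic ring, now gives a 3.0-fold lower number from compound 3 to compound 4 (0.48 log units; beyond the scatter), and the gap to the step on the other core stays within the scatter: the same change on two cores in the HCT-116 assay, a 1.3-fold lower number (0.11 log units; within the scatter) from compound 2 to compound 1 and a 3.0-fold lower number (0.48 log units; beyond the scatter) from compound 3 to compound 4, 2.3-fold (0.37 log units) apart, within the scatter of two such steps

The second change, (2-(dimethylamino)ethyl)amino in place of chloro, gives a 2.9-fold lower number from compound 1 to compound 4 (0.46 log units; beyond the scatter) on the hexyloxy core, and this too stays close to its counterpart on the ethoxy core: the same change on two cores in the HCT-116 assay, a 1.2-fold lower number (0.09 log units; within the scatter) from compound 2 to compound 3 and a 2.9-fold lower number (0.46 log units; beyond the scatter) from compound 1 to compound 4, 2.3-fold (0.37 log units) apart, within the scatter of two such steps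

Among these compounds, the two pairs of steps therefore show that, as far as can be read here, each change carries from one core to the other, but they do not show that the steps differ between cores, even though only the steps ending at compound 4 lie beyond the scatter, and each change rests on a single pair per core.

In a physicochemical assay for solubility (a higher number here means a more soluble compound, a lower number a less soluble compound), compound 3 gives > 10000 ug/mL, which is a limit of the assay and not a number. In the physicochemical assay compound 4 gives > 10000 ug/mL, which is likewise a limit of the assay. In the physicochemical assay the step from compound 3 to compound 4 cannot be read, as both values are limits: the limit of > 10000 ug/mL in the physicochemical assay, at which 2 of the 2 values shown sit.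

From the compounds shown here alone, it remains open how a butoxy or an octyloxy chain in place of hexyloxy, or a morpholine-bearing amine in place of (2-(dimethylamino)ethyl)amino, would read in the HCT-116 assay.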